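This account rests on a few compounds, and the source may have more. Where it says the series, first, only, none or still open, it means among the compounds named here.

In a functional assay on Jurkat cells (Homo sapiens) for inhibition, read by CCK-8 assay, with a stated time of 48 h (on this read-out higher numbers stand for weaker inhibition of growth and lower numbers for stronger inhibition of growth), compound 1 `CN1CCN(c2ccc(Nc3ncc(Cl)c(NCc4ccc(C(F)(F)F)cc4)n3)nc2)CC1` gives 7960 nM and compound 2 `CC(C)c1ccc(Nc2nc(Nc3ccc(N4CCN(C)CC4)cn3)ncc2Cl)cc1` gives 7530 nM so that the two lie within the scatter of each other. Among the compounds with values here, compound 3 `CC(C)c1cccc(Nc2nc(Nc3ccc(N4CCN(C)CC4)cn3)ncc2Cl)c1` carries 3-isopropylphenyl in place of 4-isopropylphenyl on a nitrogen on an aromatic ring as its only difference from compound 2, with 3-isopropylphenyl in place of 4-isopropylphenyl on a nitrogen on an aromatic ring. Within the data shown here, the one measured step at that place is a 1.1-fold lower number from compound 1 to compound 2 (0.02 log units; within the scatter) and it stays within the scatter. No step beyond the scatter is therefore expected in this assay in either direction. The expected step is a 1.1-fold lower number from compound 2 to compound 3 (0.03 log units; within the scatter) in this estimate. Compound 3 is estimated at 7000 nM (range 3000 nM to 15000 nM).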

Compound 3, concentration for 50% growth inhibition: 12300 nM
For compound 3 the middle estimate is 1.8-fold (0.24 log units) below the measured one; measured number inside the range.
By their numbers in this assay, from the lowest: compounds 2, 1 and 3 (each within the scatter of the next).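

In this assay, 3-isopropylphenyl in place of 4-isopropylphenyl on a nitrogen on an aromatic ring gives a 1.6-fold higher number from compound 2 to compound 3 (0.21 log units; within the scatter), so joining the same atoms differently does not take this place beyond the scatter. 3-isopropylphenyl in place of 4-(trifluoromethyl)benzyl gives a 1.5-fold higher number from compound 1 to compound 3 (0.19 log units; within the scatter), so none of the three groups separates from another in this assay. No independent measurement accounts for these numbers. Still open, from the compounds shown here alone, is whether an amine or a carboxylic acid on the phenyl ring at this place would give a step beyond the scatter.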